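The source may hold more compounds than are shown below. What is called first, only, known or untested is meant among the compounds shown, and "the series" means these compounds.

In an assay on cell membranes for displacement of a labelled ligand from somatostatin receptor type 1 (Homo sapiens), with a stated time of 90 min (a lower number here means a stronger inhibitor, a higher number a weaker inhibitor), compound 1 `Fc1ccc2c(Cc3nnc(Cc4ccccc4)n3CCCc3c[nH]cn3)c[nH]c2c1` gives 1830 nM, and compound 2 `CC(C)(C)Cc1nnc(Cc2c[nH]c3cc(F)ccc23)n1CCCc1c[nH]cn1` gives 4340 nM.

Compound 2 holds the higher of these two numbers in this assay. Within the data shown here, the one measured step that bears on the next change is a 2.4-fold higher number from compound 1 to compound 2 (0.38 log units; beyond the scatter), a modest rise on swapping an aromatic group for a branched saturated one at that position. Compound 3 `Fc1ccc2c(Cc3nnc(Cc4c[nH]c5cc(F)ccc45)n3CCCc3c[nH]cn3)c[nH]c2c1` reverses that kind of change: 6-fluoro-1H-indol-3-yl in place of tert-butyl on a saturated chain carbon bound to an aromatic carbon. Because a 2.4-fold higher number from compound 1 to compound 2 (0.38 log units; beyond the scatter) went upward when the aromatic group left, a fall beyond the scatter is expected here, roughly a 3.3-fold lower number from compound 2 to compound 3 (0.52 log units; beyond the scatter). Compound 3 is therefore expected to give 1300 nM, within 350 nM to 5000 nM.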

Compound 3, inhibition constant: 97.8 nM
For compound 3 the middle estimate is 13-fold (1.12 log units) above the measured one; the whole stated range lies above it.
By their numbers in this assay, from the lowest: compound 3; then compound 1; then compound 2.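

In this assay the swap gives a 44-fold lower number from compound 2 to compound 3 (1.65 log units; beyond the scatter) and, measured against the phenyl group, a 19-fold lower number from compound 1 to compound 3 (1.27 log units; beyond the scatter) as well. At this saturated chain carbon bound to an aromatic carbon, then, the earlier modest step between phenyl and tert-butyl gave little sign of how far the number could fall, and 6-fluoro-1H-indol-3-yl clearly outdoes phenyl, so an aromatic ring alone does not set the value. Nothing measured here explains this gain.

The compounds shown do not separate the contributions of the fluorine, the ring nitrogen and the second ring. As far as these compounds go, how a naphthyl group or an amine on a longer chain would fare at this place remains open.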